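A few compounds are considered here, and "the series" means these few. Any claim that something is new, unique, unknown or untested is made for them only; others in the source may bear on it.

Compound 3 `CC(Oc1ccc(Oc2ccc(Cl)cc2)cc1)C(=O)Cn1nnc(-c2ccc(C(=O)O)cc2)n1` is the most polar of the three measured compounds in a physicochemical assay for lipophilicity, read by HPLC, tested at 5 mM (a higher number here means a more lipophilic compound, a lower number a more polar compound), where it gives 3.3. Compound 2 `CCCCCCCCc1ccc(OC(C)C(=O)Cn2nnc(-c3ccc(C(=O)O)cc3)n2)cc1` gives 5.9 in this assay, and compound 1 `CC(Oc1ccc(-c2ccccc2)cc1)C(=O)Cn1nnc(-c2ccc(Cl)cc2)n1` gives 6.1, so compound 3 sits well under both. Among the compounds with values here, the one measured step that touches the position now in question is a number 2.60 log units lower from compound 2 to compound 3 (beyond the scatter), which shows that what hangs from this aromatic carbon can shift the read-out a long way.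

Compound 4 `CC(Oc1ccc(-c2ccccc2)cc1)C(=O)Cn1nnc(-c2ccc(C(=O)O)cc2)n1` is reached from compound 3 by a single change: phenyl in place of 4-chlorophenoxy on an aromatic carbon. Within the data shown here, no measured pair shows a phenyl taking the place of a 4-chlorophenoxy, so the size of this step has to be guessed from the spread among compounds 1, 2 and 3 alone. Compound 1 carries the same phenyl and stands high, but it also differs from compound 4 elsewhere, so its value is only a loose guide. Because compound 3 gives 3.3 and the change removes an oxygen and a chlorine while keeping an aromatic ring, a modest rise rather than a large one is expected, about a number 0.30 log units higher from compound 3 to compound 4 (within the scatter). Compound 4 is therefore expected to give roughly 3.6, most likely between 2.6 and 4.8.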

Compound 4, partition coefficient: 2.6
Compound 4: middle estimate off by 1.00 log units, on the high side, within the range that was stated.
By their numbers in this assay, from the lowest: compound 4; then compound 3; then compounds 2 and 1 (each within the scatter of the next).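

At this aromatic carbon, the change to phenyl moves the read-out in this assay downward, with a number 0.70 log units lower from compound 3 to compound 4 (beyond the scatter) even though the entering group keeps one six-membered aromatic ring and loses only the oxygen and the chlorine. With a number 3.30 log units lower from compound 2 to compound 4 (beyond the scatter) added to the earlier step, the three groups tried here now fall in a clear order, with octyl highest, 4-chlorophenoxy in the middle and phenyl lowest. A second place also matters, with a number 3.50 log units lower from compound 1 to compound 4 (beyond the scatter) when phenyl is held constant, so the carboxy in place of chloro carries a large step of its own. No measurement at hand explains why the numbers fall this way.

As far as these compounds go, how a short chain such as ethyl, or an amine, would stand against octyl, 4-chlorophenoxy and phenyl at this aromatic carbon remains open. Also open is whether the same order of these three groups would hold with chloro in place of the carboxy, as phenyl is the only one of them shown with both.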